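This account rests on a few compounds, and the source may have more. Where it says the series, first, only, none or still open, it means among the compounds named here.

Working notes on the series.

Among the measured compounds shown here, compound 1 `CCn1ccnc1-c1cccc(Cl)c1CCc1cc(Br)ccc1OC` gives 310 nM in an assay on isolated protein for binding affinity to Melanocortin receptor 4 (Homo sapiens) (a higher number here means a weaker inhibitor, a lower number a stronger inhibitor), the lowest of the two numbers measured so far. Compound 2 `CCC(C)n1ccnc1-c1cccc(Cl)c1CCc1cc(Br)ccc1OC` gives 2500 nM in this assay, and the step reads an 8.1-fold higher number from compound 1 to compound 2 (0.91 log units; beyond the scatter): ethyl in place of hydrogen on a saturated chain carbon bound to an aromatic nitrogen and a saturated chain carbon, which is branching at the carbon carried by the imidazole nitrogen.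

Compound 3 `COc1ccc(Br)cc1CCc1c(Cl)cccc1-c1nccn1CC1CC1` is not yet measured. Against compound 1 the change is cyclopropyl in place of methyl on a saturated chain carbon bound to an aromatic nitrogen, so the chain grows at its far end rather than at the carbon bound to the nitrogen. For the measured compounds named here, the only measured step bearing on it is the one from compound 1 to compound 2, which added carbon on the same chain and cost affinity, though the place differs. A smaller loss than that is therefore expected here, roughly a 2.3-fold higher number from compound 1 to compound 3 (0.35 log units; beyond the scatter). Compound 3 is estimated at 700 nM in this assay, within a range from 250 nM to 2000 nM.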

Compound 3, inhibition constant: 2000 nM
Compound 3: the middle estimate sits 2.9-fold (0.46 log units) below what was measured; low and high end bracket the measured number.
By their numbers in this assay, from the lowest: compound 1; then compounds 3 and 2 (each within the scatter of the next).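

Growth at the far end of the chain costs affinity as well: cyclopropyl in place of methyl on a saturated chain carbon bound to an aromatic nitrogen gives a 6.5-fold higher number from compound 1 to compound 3 (0.81 log units; beyond the scatter) in this assay, so the loss is not confined to branching at the carbon bound to the nitrogen. Cyclopropylmethyl and sec-butyl on the aromatic nitrogen cannot be told apart, with a 1.3-fold lower number from compound 2 to compound 3 (0.10 log units; within the scatter) as the reading, and of the three groups shown ethyl alone stands apart from the others. No measurement at hand accounts for the loss on either change.

Open, from the compounds shown here alone, is whether a methyl or a bare hydrogen in place of ethyl on the aromatic nitrogen would hold or improve the number for compound 1. Also open, going by these compounds, is how a chain ending in an amine or a carboxylic acid would read here.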